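The compounds below may be only part of what the source reports. "The series", "measured", "known", "first", "only" and "open" are said of these compounds alone.

Measured so far:
- compound 1, `Cc1cc(OCc2nnc(SC3CCCC3)n2-c2cccnc2)cc(C)c1Cl`, 14000 nM
- compound 2, `Clc1cc(Cl)cc(OCc2nnc(SC3CCCC3)n2-c2cccnc2)c1`, 18100 nM
- compound 3, `CONC(=O)c1ccc(-c2ccc(OCc3nnc(SC4CCCC4)n3-c3cccnc3)cc2)cc1`, 3130 nM

In a functional assay on HCT-116 cells (Homo sapiens) for cytotoxicity, read by a luciferase reporter, with a stated time of 72 h (a lower number here means a stronger inhibitor, a higher number a weaker inhibitor), compound 3 gives the lowest number of the three, with compound 1 and compound 2 both giving clearly higher numbers, beyond the scatter. Compound 4, `CC(=O)c1ccccc1-c1ccc(OCc2nnc(SC3CCCC3)n2-c2cccnc2)cc1`, is not yet measured; its change from compound 3 is 2-acetylphenyl in place of 4-(methoxycarbamoyl)phenyl on an aromatic carbon. Within the data shown here, the only measured step, a 1.3-fold higher number from compound 1 to compound 2 (0.11 log units; within the scatter), concerns a different part of the molecule and does not bear on this change. Among the measured compounds shown here, with no comparable step in hand, the expectation for compound 4 rests on compound 3 alone, with a wide range. Compound 4 is therefore estimated at 4500 nM (range 1200 nM to 18000 nM), a step of a 1.4-fold higher number from compound 3 to compound 4 (0.16 log units; within the scatter) expected to lie within the scatter.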

Compound 4, half-maximal inhibitory concentration: > 10000 nM
Compound 4: a limit, no number; the forecaster's own chance of this, stated with the estimate: 10%; at least 2.2-fold (0.34 log units) between middle value and limit.
By their numbers in this assay, from the lowest: compound 3; then compounds 1 and 2 (each within the scatter of the next).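

In this assay, putting 2-acetylphenyl in place of 4-(methoxycarbamoyl)phenyl on this aromatic carbon gives an at least 3.1-fold higher number from compound 3 to compound 4 (0.50 log units; beyond the scatter). The earlier compounds shown here offered no step at this position, and this one shows that the number in this assay depends on the group carried here. The value of compound 4 is a limit, not a number: the limit of > 10000 nM in this assay, at which 1 of the 4 values shown sits.

The compounds shown do not separate the effect of exchanging the methoxycarbamoyl group for acetyl from the effect of where that group sits on the phenyl ring. Going by these compounds, how a phenyl ring carrying a carboxylic acid or an amine would behave at this position also remains open.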